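Aryl substituent variation on the shared bicyclic amino acid core

A few compounds are considered here, and "the series" means these few. Any claim that something is new, unique, unknown or untested is made for them only; others in the source may bear on it.

Compound 1 `N[C@]1(C(=O)O)[C@H]2[C@@H](C[C@H]1OCc1cccc(Br)c1)[C@]2(F)C(=O)O`: in an assay on CHO cells for binding affinity to metabotropic glutamate receptor 2 (Rattus norvegicus) (a lower number here means a stronger inhibitor, a higher number a weaker inhibitor), compound 1 gives 4.71 nM.
Compound 2 `N#Cc1cccc(CO[C@@H]2C[C@@H]3[C@H]([C@]2(N)C(=O)O)[C@@]3(F)C(=O)O)c1`: in this assay compound 2 gives 2.94 nM.

Among the two numbers the value of compound 2 sits at the low end, with compound 1 nearest; the step of a 1.6-fold lower number from compound 1 to compound 2 (0.20 log units; within the scatter) stays within the scatter. Compound 3 `N[C@]1(C(=O)O)[C@H]2[C@@H](C[C@H]1OCc1cccc(F)c1F)[C@]2(F)C(=O)O` carries 2,3-difluorophenyl in place of 3-cyanophenyl on a saturated chain carbon bound to an oxygen on a saturated carbon. Among the compounds with values here, the one measured step that bears on this change, a 1.6-fold lower number from compound 1 to compound 2 (0.20 log units; within the scatter), exchanges one ring substituent for another without a shift beyond the scatter, so no step beyond the scatter is expected in this assay here either. Compound 3 is therefore estimated at 4 nM (range 1.5 nM to 12 nM), the expected step being a 1.4-fold higher number from compound 2 to compound 3 (0.13 log units; within the scatter).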

Compound 3, inhibition constant: 4.25 nM
The estimate for compound 3 lay 1.1-fold (0.03 log units) below the measured number; the range from low to high includes it.
By their numbers in this assay, from the lowest: compounds 2, 3 and 1 (each within the scatter of the next).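

In this assay, the position on a saturated chain carbon bound to an oxygen accepts 2,3-difluorophenyl in place of either earlier aryl group: a 1.4-fold higher number from compound 2 to compound 3 (0.16 log units; within the scatter) and a 1.1-fold lower number from compound 1 to compound 3 (0.04 log units; within the scatter). The change also removes the nitrile with its hydrogen-bond acceptor, and no step beyond the scatter accompanies that loss. No further data bear on why these three aryl groups read alike.

Open, as far as these compounds go, is whether an amine or a carboxylic acid on the phenyl ring would shift the number beyond the scatter. From the compounds shown here alone, a longer chain in place of the saturated chain carbon also remains untested here.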